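The source may hold more compounds than are shown below. What is called first, only, known or untested is meant among the compounds shown, and "the series" means these compounds.

For the measured compounds named here, in a functional assay on Ramos cells (Homo sapiens) for antiproliferative activity, read by CCK-8 assay, with a stated time of 48 h (on this read-out lower numbers stand for stronger inhibition and higher numbers for weaker inhibition), compound 1 `C=CC(=O)Nc1cccc(-n2cnc3cnc(Nc4ccc(N5CCN(C)CC5)cc4)nc32)c1` gives 8220 nM, the only actual number among the three values shown. Compound 2 `C=CC(=O)Nc1cccc(-n2cnc3cnc(Nc4ccc(N5CCN(S(C)(=O)=O)C(C)C5)cc4)nc32)c1` reads > 40000 nM, which is a limit. Compound 3 `C=CC(=O)Nc1cccc(-n2cnc3cnc(Nc4ccc(N5CCN(S(C)(=O)=O)CC5)cc4)nc32)c1` reads > 40000 nM, also a limit. Compound 4 `C=CC(=O)Nc1cccc(-n2cnc3cnc(Nc4ccc(N5CCN(C)CC5)cc4OC)nc32)c1` keeps the 4-methylpiperazin-1-yl group of compound 1 and instead carries methoxy in place of hydrogen on an aromatic carbon. Two measured steps, an at least 4.8-fold higher number from compound 1 to compound 2 (0.68 log units; beyond the scatter) and an at least 4.8-fold higher number from compound 1 to compound 3 (0.68 log units; beyond the scatter), lie beyond the scatter, but both alter the 4-methylpiperazin-1-yl group, so they bear only indirectly on this change. Going by the values given here, no measured step touches that aromatic carbon. The expected step in this assay is a 1.4-fold lower number from compound 1 to compound 4 (0.14 log units; within the scatter), which is estimated to stay within the scatter. For compound 4 the estimated value is 6000 nM, with an expected range of 2000 nM to 20000 nM.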

Compound 4, half-maximal inhibitory concentration: 13200 nM
Compound 4: middle estimate off by 2.2-fold (0.34 log units), on the low side; low and high end bracket the measured number.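

In this assay, methoxy in place of hydrogen on an aromatic carbon, ortho to a large group, gives a 1.6-fold higher number from compound 1 to compound 4 (0.21 log units; within the scatter). This is the only measured change at this carbon among the compounds shown, and it shows that methoxy is taken up here without a difference from hydrogen that can be told from the scatter. Compound 2 and compound 3 remain limits and not numbers: the limit of > 40000 nM in this assay, at which 2 of the 4 values shown sit.

As far as these compounds go, whether fluorine, a hydroxyl or an amine on this carbon would behave like methoxy stays open. So does whether methoxy would have the same effect alongside the methylsulfonyl-bearing piperazine groups.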